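What to Expect from Compound 4

The source may report more compounds than this note shows. Statements on the series, on what has been measured and on what is new or still open speak of the compounds shown alone.

Compound 1 (`Cc1ccccc1OCCn1ccc(=O)n(Cc2ccccc2)c1=O`) gives 117000 nM
Compound 2 (`O=c1ccn(CCOc2ccc(F)cc2)c(=O)n1Cc1ccccc1`) gives 187000 nM
Compound 3 (`Cc1ccc(OCCn2ccc(=O)n(Cc3ccccc3C)c2=O)cc1`) gives 46000 nM

In an ADME assay on MT4 cells (Homo sapiens) for cytotoxicity, read by MTT assay, with a stated time of 4 days (on this read-out higher numbers stand for lower toxicity in this test and lower numbers for higher toxicity in this test), compound 3 has the lowest of these three numbers (46000 nM), and its gaps to compound 1 and compound 2 both lie beyond the usual scatter. Compound 4 (`Cc1ccc(OCCn2ccc(=O)n(Cc3c(C)cc(C)cc3C)c2=O)cc1`) carries 2,4,6-trimethylphenyl in place of 2-methylphenyl on a saturated chain carbon bound to an aromatic nitrogen. Among the compounds with values here, only one measured step changes a single place (a 1.6-fold higher number from compound 1 to compound 2 (0.20 log units; within the scatter)). It concerns a different group, on an oxygen on a saturated carbon, and it stays within the scatter. Within the data shown here, no measured step changes the group at the place altered in compound 4, so the guidance is indirect. Compound 3 differs from compound 1 in more than one place, so their gap cannot be assigned to one change. In this assay no shift beyond the scatter is therefore expected, and the estimated change is small (a 1.2-fold lower number from compound 3 to compound 4 (0.06 log units; within the scatter)). For compound 4 the estimated value is 40000 nM (expected range 14000 nM to 110000 nM).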

Compound 4, half-maximal cytotoxic concentration: 133000 nM
Beside the measured number, compound 4's estimate is 3.3-fold (0.52 log units) below it; measured number outside the range, above it.
By their numbers in this assay, from the lowest: compound 3; then compounds 1, 4 and 2 (each within the scatter of the next).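

In this assay, putting 2,4,6-trimethylphenyl in place of 2-methylphenyl gives a 2.9-fold higher number from compound 3 to compound 4 (0.46 log units; beyond the scatter) at this position, on a saturated chain carbon bound to an aromatic nitrogen. This is the first single-place change shown here, and unlike the earlier step on an oxygen on a saturated carbon, it lies beyond the scatter, so this position can change the number, here in the direction of lower toxicity in this test. No measurement offered here accounts for the shift.

The compounds shown cannot tell which of the added methyl groups carries the shift, or whether one alone would be enough. They also leave open how this read-out would respond if an amine or a carboxylic acid stood on this phenyl ring.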